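Methoxy to ethoxy on the chloro quinone, compound 2

The compounds below may be only part of what the source reports. "The series", "measured", "known", "first", "only" and "open" are said of these compounds alone.

compound 1 `CC(=O)Oc1cc(OC(C)=O)c2c(OC(C)=O)c(C)cc(Cl)c2c1OC(C)=O`: 53500 nM
compound 2 `COc1cc(C)c(Cl)c2c1C(=O)C=CC2=O`: 24600 nM
compound 3 `Cc1cc(O)c2c(c1F)C(=O)C=CC2=O`: 18900 nM

All three numbers come from a functional assay on SNO cells (Homo sapiens) for cytotoxicity, read by XTT assay, with a stated time of 24 h; on this read-out higher numbers stand for weaker inhibition and lower numbers for stronger inhibition. Compound 2 reads 24600 nM, which lies within the usual scatter of compound 3 at 18900 nM. Compound 1 reads 53500 nM, a higher number than that of compound 2, and this gap lies beyond the scatter. The three compounds differ from one another in more than one place, so the series offers no measured single change to serve as a guide.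

The next compound to be measured is compound 4 `CCOc1cc(C)c(Cl)c2c1C(=O)C=CC2=O`. Its difference from compound 2 is methyl in place of hydrogen on a saturated chain carbon bound to an oxygen on an aromatic ring, or methoxy to ethoxy when cut one bond further out. The rest of the structure stays the same.

Among the measured compounds shown here, with no measured step to draw on, the expectation starts from compound 2 at 24600 nM and from the small size of the change. The step of a 1.1-fold lower number from compound 2 to compound 4 (0.05 log units; within the scatter) is expected to remain within the scatter in this assay, with no clear direction. The estimated value for compound 4 is 22000 nM, with an expected range of 11000 nM to 43000 nM.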

Compound 4, half-maximal inhibitory concentration: 44200 nM
Beside the measured number, compound 4's estimate is 2.0-fold (0.30 log units) below it; the whole stated range lies below it.
By their numbers in this assay, from the lowest: compounds 3, 2, 4 and 1 (each within the scatter of the next, the first and the last beyond it).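

In this assay, the series now holds its first measured single change, a step of a 1.8-fold higher number from compound 2 to compound 4 (0.25 log units; within the scatter), for methyl in place of hydrogen on a saturated chain carbon bound to an oxygen on an aromatic ring. Cut one bond further out, this is methoxy to ethoxy on the shared core, and at this position the pair gives no change that can be told apart from repeat-measurement noise, so neither a gain nor a loss can be assigned to the added methyl. That reading rests on this one pair alone, and no supporting measurement bears on the result.

The compounds shown leave open whether this position stays as unresponsive to a longer chain such as propyl on the same oxygen, or to a chain ending in an amine or a carboxylic acid. Among the compounds shown here, they also leave open whether methoxy to ethoxy reads the same on a core without the chlorine of compound 2, since no second matched pair for this change is available.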